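A Methoxy Step Within a Series Lacking Measurable Potency

This account rests on a few compounds, and the source may have more. Where it says the series, first, only, none or still open, it means among the compounds named here.

The study compares three measured compounds and one unmeasured compound in a functional assay on MCF7 cells (Homo sapiens) for antiproliferative activity, read by WST assay, with a stated time of 72 h; on this read-out lower numbers stand for stronger inhibition and higher numbers for weaker inhibition. Compound 1 `Clc1ccc(-c2noc(-c3cc4ccccc4[nH]3)n2)cc1` gives in this assay only a limit, > 50000 nM. Compound 2 `COc1ccc2[nH]c(-c3nc(-c4ccc(Cl)cc4)no3)cc2c1` likewise gives a limit, > 50000 nM. Compound 3 `COc1ccc(-c2noc(-c3cc4ccccc4[nH]3)n2)cc1` also gives a limit, > 50000 nM. Compound 2 differs from compound 1 by methoxy in place of hydrogen on an aromatic carbon, and the step that the two limits leave unreadable from compound 1 to compound 2 cannot be sized because of the limit of > 50000 nM in this assay, at which 3 of the 3 values shown sit. Compound 3 differs from compound 1 by methoxy in place of chloro on an aromatic carbon, and here too the step that the two limits leave unreadable from compound 1 to compound 3 stays unreadable because of the limit of > 50000 nM in this assay, at which 3 of the 3 values shown sit. Compound 4 `COc1ccc(-c2noc(-c3cc4cc(OC)ccc4[nH]3)n2)cc1` differs from compound 3 by methoxy in place of hydrogen on an aromatic carbon, the same change that leads from compound 1 to compound 2, placed on the other core. With every measured value sitting at the limit, there is no readable step on which a direction could rest. The step that the limit leaves unreadable from compound 3 to compound 4 is therefore expected to be negligible, resting on the unreadable earlier step that the two limits leave unreadable from compound 1 to compound 2. Compound 4 is expected to give about 60000 nM, most likely again as a limit, with an estimated range from 20000 nM to 200000 nM.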

Compound 4, half-maximal inhibitory concentration: > 50000 nM
Compound 4 ended at the assay's limit; the forecaster's own chance of this, stated with the estimate: 85%; the middle value lies beyond the limit too.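

No size can be given for the step to compound 4 from either compound 3 or compound 2, because neither compound of either pair gives a number: the limit of > 50000 nM in this assay, at which 4 of the 4 values shown sit. The compounds shown leave open whether any of these methoxy changes affects antiproliferative activity at all, and which structures in this series would give a value short of the limit.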